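Cytotoxicity notes: methyl placement on the aryl ether

This account rests on a few compounds, and the source may have more. Where it says the series, first, only, none or still open, it means among the compounds named here.

Of the compounds shown here, three sharing one core have been measured in an ADME assay on MT4 cells (Homo sapiens) for cytotoxicity, read by MTT assay, with a stated time of 4 days; a higher number here means that more compound is tolerated, a lower number that less compound is tolerated. Compound 1 `N#Cc1ccc(Nc2nc(Oc3ccccc3Cl)c3ccccc3n2)cc1` gives 38000 nM. Compound 2 `Cc1cccc(Oc2nc(Nc3ccc(C#N)cc3)nc3ccccc23)c1` gives 355000 nM and stands highest of the three: the step of a 9.3-fold higher number from compound 1 to compound 2 (0.97 log units; beyond the scatter) and the step of a 14-fold lower number from compound 2 to compound 3 (1.15 log units; beyond the scatter) both lie beyond the scatter. Compound 3 `Cc1cc(Br)c(Oc2nc(Nc3ccc(C#N)cc3)nc3ccccc23)c(Br)c1` gives 25000 nM, and the step of a 1.5-fold lower number from compound 1 to compound 3 (0.18 log units; within the scatter) is within the scatter.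

Compound 4 `Cc1ccccc1Oc1nc(Nc2ccc(C#N)cc2)nc2ccccc12` is not yet measured. Against compound 2 the change is 2-methylphenyl in place of 3-methylphenyl on an oxygen on an aromatic ring.

Among the compounds with values here, two measured steps bear on this. Compound 1, carrying 2-chlorophenyl, and compound 3, carrying 2,6-dibromo-4-methylphenyl, both sit well below compound 2, which carries 3-methylphenyl, by a 9.3-fold higher number from compound 1 to compound 2 (0.97 log units; beyond the scatter) and a 14-fold lower number from compound 2 to compound 3 (1.15 log units; beyond the scatter). Compound 4 carries 2-methylphenyl, a group closer in its substitution pattern to those of compound 1 and compound 3 than to that of compound 2. Since only methyl moves, a drop is expected in this assay beyond the scatter but smaller than the steps to compound 1 or compound 3.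

The estimate for compound 4 is therefore 90000 nM, with a range of 25000 nM to 320000 nM, corresponding to an expected step of a 3.9-fold lower number from compound 2 to compound 4 (0.60 log units; beyond the scatter).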

Compound 4, half-maximal cytotoxic concentration: 355000 nM
Beside the measured number, compound 4's estimate is 3.9-fold (0.60 log units) below it; the whole stated range lies below it.
By their numbers in this assay, from the lowest: compounds 3 and 1 (each within the scatter of the next); then compounds 2 and 4 (each within the scatter of the next).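

In this assay, 2-methylphenyl in place of 3-methylphenyl on the oxygen gives no change at the digits printed from compound 2 to compound 4 (within the scatter), so for these two groups the place of the methyl on the ring does not separate the numbers. Methyl in place of chloro on the aromatic carbon gives a 9.3-fold higher number from compound 1 to compound 4 (0.97 log units; beyond the scatter), and 2-methylphenyl in place of 2,6-dibromo-4-methylphenyl gives a 14-fold higher number from compound 3 to compound 4 (1.15 log units; beyond the scatter), so among these four compounds the two lower numbers go with the halogen-bearing aryl groups, and none of the four goes against this. No measurement at hand gives a reason for this pattern.

On these data alone, the chloro and methyl groups have been compared on the ring only in the 2-substituted pair, so whether a 3-chlorophenyl group would stay with compound 1 or with compound 2 remains open, as does the reading for an unsubstituted phenyl group. Compound 3 also changes several ring substituents at once, so the share of the two bromines cannot be separated from that of the methyl, and a 2-aminophenyl or 2-carboxyphenyl group would test whether the tolerance extends beyond methyl.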